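Swapping isobutyl for 3-methoxyphenyl on the shared core

The source may report more compounds than this note shows. Statements on the series, on what has been measured and on what is new or still open speak of the compounds shown alone.

Compound 1 `COc1cc(-c2nccn2C(C)C)cc(OC)c1OC` and compound 2 `COc1cc(-c2nccn2CC(C)C)cc(OC)c1OC` differ only in the group on an aromatic nitrogen. In a functional assay on HCT-15 cells (Homo sapiens) for antiproliferative activity, read by MTT assay, with a stated time of 72 h (a lower number here means a stronger inhibitor, a higher number a weaker inhibitor), compound 1 gives > 100000 nM, which is a limit of the assay. In this assay compound 2 gives > 100000 nM, also a limit. Within the data shown here, the only measured change is a step that the two limits leave unreadable from compound 1 to compound 2. Among the measured compounds shown here, both compounds stand at the limit of > 100000 nM in this assay, at which 2 of the 2 values shown sit, so no measured step gives a size to carry forward.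

Compound 3 `COc1cccc(-n2ccnc2-c2cc(OC)c(OC)c(OC)c2)c1` brings a larger change: 3-methoxyphenyl in place of isobutyl on an aromatic nitrogen. For the measured compounds named here, no measured compound carries an aromatic group at this place, so the expectation rests on that structural difference alone. Any readable step could only point toward stronger inhibition, and a result at the limit remains possible. The expected move is an at least 12-fold lower number from compound 2 to compound 3 (1.09 log units; beyond the scatter), a loose estimate. For compound 3 the estimated value is 8000 nM, with an expected range of 500 nM to 100000 nM.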

Compound 3, half-maximal inhibitory concentration: 17100 nM
Compound 3: the middle estimate sits 2.1-fold (0.33 log units) below what was measured; the range from low to high includes it.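

In this assay this position on an aromatic nitrogen can move the read-out: 3-methoxyphenyl in place of isobutyl gives an at least 5.8-fold lower number from compound 2 to compound 3 (0.76 log units; beyond the scatter) and 3-methoxyphenyl in place of isopropyl gives an at least 5.8-fold lower number from compound 1 to compound 3 (0.76 log units; beyond the scatter) on the shared core. The step between isopropyl and isobutyl cannot be read, so 3-methoxyphenyl is the first group shown at this place to bring a value inside the measurable range. Both new steps give only a minimum size, because compound 1 and compound 2 remain at a limit: the limit of > 100000 nM in this assay, at which 2 of the 3 values shown sit.

The compounds shown do not separate the contribution of the aromatic ring from that of its methoxy group, a question that a plain phenyl or a benzyl group would bear on. Going by these compounds, how an amine or a carboxylic acid on that ring would change the read-out also remains open.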